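The compounds below may be only part of what the source reports. "The series", "measured", "known", "first", "only" and "open" are said of these compounds alone.

Measured so far in a functional assay on T-24 cells (Homo sapiens) for antiproliferative activity, read by MTT assay, with a stated time of 48 h; on this read-out lower numbers stand for stronger inhibition and higher numbers for weaker inhibition:
compound 1, `Cc1ccc(NC(=O)Nc2cccc(CNc3nccnc3Cl)c2)cc1`, gives 9820 nM;
compound 2, `O=C(Nc1cccc(CNc2nccnc2Cl)c1)Nc1ccccc1Cl`, gives 6680 nM;
compound 3, `CCc1ccc(NC(=O)Nc2cccc(CNc3nccnc3Cl)c2)c(CC)c1`, gives 6390 nM.

Compound 2 sits among these three values with compound 3 nearest and compound 1 furthest, and all three lie within the usual scatter of one another. Compound 4, `O=C(Nc1ccc(Cl)cc1)Nc1cccc(CNc2nccnc2Cl)c1`, differs from compound 2 in one place: 4-chlorophenyl in place of 2-chlorophenyl on an amide-type nitrogen. Going by the values given here, the only measured step that touches this position, a 1.5-fold lower number from compound 1 to compound 2 (0.17 log units; within the scatter), exchanged one ring for another on the same amide-type nitrogen and stayed within the scatter. On that basis a step of a 1.0-fold lower number from compound 2 to compound 4 (0.01 log units; within the scatter) in this assay is expected, that is, nothing beyond the scatter. Compound 4 is therefore estimated at 6500 nM, with a range from 3000 nM to 14000 nM.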

Compound 4, half-maximal inhibitory concentration: 5470 nM
Compound 4: the middle estimate sits 1.2-fold (0.07 log units) above what was measured, within the range that was stated.
By their numbers in this assay, from the lowest: compounds 4, 3, 2 and 1 (each within the scatter of the next).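

Exchanging 2-chlorophenyl for 4-chlorophenyl on the amide-type nitrogen keeps the same atoms and joins them differently, and in this assay this gives a 1.2-fold lower number from compound 2 to compound 4 (0.09 log units; within the scatter) so the two chlorine placings cannot be told apart here. Chloro in place of methyl on an aromatic carbon gives a 1.8-fold lower number from compound 1 to compound 4 (0.25 log units; within the scatter) so that exchange cannot be told apart from the scatter either. Nothing available explains these results. On these data alone, whether an amine or a carboxylic acid on this ring would give a step beyond the scatter remains open.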